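Fused Heteroaromatic Ring in Place of Plain Phenyl

This account rests on a few compounds, and the source may have more. Where it says the series, first, only, none or still open, it means among the compounds named here.

Compound 1 `O=c1c(-c2cccc([N+](=O)[O-])c2)nc2ccccc2n1Cc1ccccc1` gives 9 nM in an assay on cells for activation of Cystic fibrosis transmembrane conductance regulator (Homo sapiens), read by fluorescence, with a stated time of 10 min; on this read-out lower numbers stand for an effect already at smaller amounts and higher numbers for an effect only at larger amounts of compound.
Compound 2 `O=c1c(-c2ccc([N+](=O)[O-])cc2)nc2ccccc2n1Cc1ccccc1` gives 1000 nM in this assay.
Compound 3 `O=c1c(-c2ccccc2)nc2ccccc2n1Cc1ccccc1` gives 5000 nM in this assay.

Compound 3 has the highest number of the three, so it needs the largest amount for an effect. The step of a 5.0-fold higher number from compound 2 to compound 3 (0.70 log units; beyond the scatter) is modest, while a 560-fold higher number from compound 1 to compound 3 (2.74 log units; beyond the scatter) is large, and a 110-fold higher number from compound 1 to compound 2 (2.05 log units; beyond the scatter) is large too. Compound 4 `O=c1c(-c2ccc3nonc3c2)nc2ccccc2n1Cc1ccccc1` differs from compound 3 by a group of 9 heavy atoms (6 carbon, 2 nitrogen, 1 oxygen; one five-membered aromatic ring with 3 hetero atoms, one six-membered aromatic ring of carbon only) in place of a group of 6 heavy atoms (6 carbon; one six-membered aromatic ring of carbon only), on an aromatic carbon. For the measured compounds named here, no measured step carries exactly this change, yet both nitro compounds show that adding heteroatoms to this ring lowered the number, and the place on the ring decided how much. The expected step is a 33-fold lower number from compound 3 to compound 4 (1.52 log units; beyond the scatter). Compound 4 is estimated at 150 nM, within 15 nM to 1500 nM.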

Compound 4, half-maximal effective concentration: 18 nM
Compound 4: the middle estimate sits 8.3-fold (0.92 log units) above what was measured, and the stated range covers the measured number.
By their numbers in this assay, from the lowest: compounds 1 and 4 (each within the scatter of the next); then compound 2; then compound 3.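

With a 280-fold lower number from compound 3 to compound 4 (2.44 log units; beyond the scatter), a nitro group is not needed for a low number here: the fused ring with its five-membered hetero ring does this too. Measured against the 3-nitrophenyl group, the change gives a 2.0-fold higher number from compound 1 to compound 4 (0.30 log units; within the scatter), so these two compounds cannot be told apart, while against the 4-nitrophenyl group it gives a 56-fold lower number from compound 2 to compound 4 (1.74 log units; beyond the scatter). No measured property of these groups is available to account for this.

On these data alone, whether an amine or a carboxylic acid on the phenyl would also lower the number remains open, as does whether the fused ring keeps its effect with a longer chain in place of the benzyl group.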